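The source may hold more compounds than are shown below. What is called first, only, known or untested is meant among the compounds shown, and "the series" means these compounds.

Measured so far in a functional assay on HT-29 cells (Homo sapiens) for antiproliferative activity, read by sulforhodamine B assay, with a stated time of 72 h; a higher number here means a weaker inhibitor, a lower number a stronger inhibitor:
compound 1 `NC(=S)N/N=C/c1nc2ccccc2s1`: > 100000 nM.
compound 2 `Cc1ccc(NC(=S)N/N=C/c2ccc3ccccc3n2)cc1`: 85500 nM.

The value of compound 1 is a limit of this assay, not a number. Compound 2 holds the only number shown in this assay; the one other value is a limit (the limit of > 100000 nM in this assay, at which 1 of the 2 values shown sits). Compound 3 `S=C(N/N=C/c1ccc2ccccc2n1)Nc1ccccc1` differs from compound 2 by hydrogen in place of methyl on an aromatic carbon, 4-methylphenyl becoming phenyl. Among the compounds with values here, no measured pair of this kind is available, so no step size for this change is known. The step from compound 2 to compound 3 in this assay is expected to stay within the usual scatter, a 1.1-fold higher number from compound 2 to compound 3 (0.05 log units; within the scatter). Compound 3 is estimated at 95000 nM in this assay, between 40000 nM and 250000 nM.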

Compound 3, half-maximal inhibitory concentration: 17000 nM
Estimate against measurement, compound 3: 5.6-fold (0.75 log units) above; the measured number lies below the stated range.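

In this assay, hydrogen in place of methyl on an aromatic carbon, para to a large group, gives a 5.0-fold lower number from compound 2 to compound 3 (0.70 log units; beyond the scatter). Within the data shown here, this is the first measured single-place step, and it shows that this position is not silent: 4-methylphenyl to phenyl moves the number beyond the scatter, towards the stronger side. Nothing shown here gives a cause for this step.

From the compounds shown here alone, whether a chlorine, a methoxy group or an amine at this position would keep or lose the gain remains open. So does whether the same change behaves alike on another core.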